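A few compounds are considered here, and "the series" means these few. Any claim that something is new, unique, unknown or untested is made for them only; others in the source may bear on it.

Working notes on the sulfonyl-imine urea series, lipophilicity.

Three compounds carry a number in a physicochemical assay for lipophilicity; on this read-out higher numbers stand for higher lipophilicity and lower numbers for lower lipophilicity. Compound 1 `O=C(Nc1ccc(Cl)cc1)Nc1ccc2c(c1)C(Nc1ccc(Cl)cc1Cl)=NS2(=O)=O` gives 4.24. Compound 3 `O=C(Nc1ccc(OC2=NS(=O)(=O)c3ccccc32)cc1)Nc1ccccc1Cl` gives 3.55. Compound 2 `O=C(Nc1ccc(NC2=NS(=O)(=O)c3ccccc32)cc1)Nc1cccc(Br)c1` gives 2.24, the lowest of the three: compound 3 stands higher by a gap beyond the scatter, and compound 1 stands higher still, also beyond the scatter. No two of these compounds differ in one place only, so their gaps are read as plain differences between whole structures and not as single steps.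

Compound 4 `COc1ccc(NC(=O)Nc2ccc(NC3=NS(=O)(=O)c4ccccc43)cc2)cc1` is not yet measured in this assay. Set against compound 2 the change is 4-methoxyphenyl in place of 3-bromophenyl on an amide-type nitrogen. On the basis of the bromine leaving and the methoxy entering, the step expected from compound 2 to compound 4 in this assay is a number 0.84 log units lower from compound 2 to compound 4 (beyond the scatter), downward and beyond the scatter. Compound 4 is therefore estimated at 1.4, within the range 0.8 to 2; the measurement will show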

Compound 4, partition coefficient: 2.99
Compound 4: the middle estimate sits 1.59 log units below what was measured; the whole stated range lies below it.
By their numbers in this assay, from the lowest: compound 2; then compound 4; then compound 3; then compound 1.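

Going by these compounds alone, this is the first step that can be read at a single place: on an amide-type nitrogen, 4-methoxyphenyl in place of 3-bromophenyl gives a number 0.75 log units higher from compound 2 to compound 4 (beyond the scatter) in this assay. The group on this nitrogen therefore moves the read-out by more than the scatter, and the move is upward even though the entering group counts one hydrogen-bond acceptor and the leaving group none. Nothing available on these compounds bears on the reason for this rise.

This single step cannot separate the bromine leaving from the methoxy entering, and an unsubstituted phenyl on the same nitrogen would be needed to divide it. Going by these compounds, whether the same change gives a similar step on the core of compound 3 stays open, as does the result of a carboxylic acid on this aromatic ring.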